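The source may hold more compounds than are shown below. What is called first, only, known or untested is meant among the compounds shown, and "the series" means these compounds.

Compound 1 `Cc1noc(NS(=O)(=O)c2cccc3c(Cl)cccc23)c1C` and compound 2 `Cc1cnoc1NS(=O)(=O)c1cccc2c(N(C)C)cccc12` share a core and were tested in an assay on VSM-A10 cells for antagonist activity at Endothelin-1 receptor (Rattus norvegicus); on this read-out lower numbers stand for stronger inhibition and higher numbers for weaker inhibition. Compound 1 gives 24000 nM, the higher of the two numbers, while compound 2 gives 4900 nM, a gap beyond the usual scatter. Compound 3 `CCOC(=O)C(C)Nc1cccc2c(S(=O)(=O)Nc3onc(C)c3C)cccc12` has not yet been measured. Relative to compound 1 it carries the change ((1-(ethoxycarbonyl)ethyl)amino in place of chloro on an aromatic carbon). Since compound 2, the only other reference, gives 4900 nM with an amino-type group at that carbon, the step is expected to go toward a lower number, beyond the scatter, as a 4.8-fold lower number from compound 1 to compound 3 (0.68 log units; beyond the scatter). Compound 3 is therefore estimated at 5000 nM, between 1000 nM and 25000 nM.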

Compound 3, half-maximal inhibitory concentration: 400 nM
Compound 3: the middle estimate sits 13-fold (1.10 log units) above what was measured; the whole stated range lies above it.
By their numbers in this assay, from the lowest: compound 3; then compound 2; then compound 1.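

Putting (1-(ethoxycarbonyl)ethyl)amino in place of chloro on this aromatic carbon brings a 60-fold lower number from compound 1 to compound 3 (1.78 log units; beyond the scatter) and shows that the carbon can carry a far larger chain, with 8 heavy atoms instead of 1, while the number falls rather than rises. Nothing measured here explains why the number falls so far. The compounds shown leave open whether the linking nitrogen alone accounts for the step or the ester part of the chain also contributes. A plain amino group, or a carboxylic acid in place of the ethyl ester, would help separate these two parts.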